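Methyl in place of hydrogen on compound 3

A few compounds are considered here, and "the series" means these few. Any claim that something is new, unique, unknown or untested is made for them only; others in the source may bear on it.

Measured so far in an in vitro ADME assay on microsomes from liver (Rattus norvegicus) for metabolic stability (a lower number here means that the compound disappears faster, a higher number that the compound lasts longer), for the series:
compound 1 `Cc1c2c(n3c1CCCNC[C@H](C)Nc1cc-3ccc1C(N)=O)CC(C)(C)CC2=O` gives > 0.5 h as a limit
compound 2 `Cc1c2c(n3c1CCNCC(O)CNc1cc-3ccc1C(N)=O)CC(C)(C)CC2=O` gives 0.167 h as a number
compound 3 `Cc1c2c(n3c1CNCCCCNc1cc-3ccc1C(N)=O)CC(C)(C)CC2=O` gives 0.3 h as a number

The entry for compound 1 is a limit of the assay and not a number. Compound 2 at 0.167 h and compound 3 at 0.3 h lie within the scatter of each other, so these two numbers do not separate the compounds.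

Compound 4 `Cc1c2c(n3c1CNCCC[C@H](C)Nc1cc-3ccc1C(N)=O)CC(C)(C)CC2=O` has not yet been measured. It comes from compound 3 by a single change methyl in place of hydrogen on a saturated ring carbon with methyl in place of hydrogen on a saturated ring carbon. Within the data shown here, no measured pair isolates this change, so any expectation is weakly founded. The expected step of a 1.3-fold higher number from compound 3 to compound 4 (0.12 log units; within the scatter) in this assay is slightly upward and stays within the scatter. For compound 4 the estimated half-life is 0.4 h with an expected range from 0.18 h to 0.8 h in this estimate.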

Compound 4, half-life in the Rattus norvegicus assay: 0.117 h
For compound 4 the middle estimate is 3.4-fold (0.53 log units) above the measured one; the whole stated range lies above it.
By their numbers in the Rattus norvegicus assay, from the lowest: compounds 4, 2 and 3 (each within the scatter of the next, the first and the last beyond it). At a limit, above all of these: compound 1.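

In the Rattus norvegicus assay compound 3 gives 0.3 h and compound 4 gives 0.117 h. Among these compounds, in the Rattus norvegicus assay the only pair isolating this change gives a 2.6-fold lower number from compound 3 to compound 4 (0.41 log units; beyond the scatter), so methyl in place of hydrogen on a saturated ring carbon of the non-aromatic ring shortens the half-life here, which compounds differing in more than one place could not show. In a physicochemical assay for solubility (on this read-out lower numbers stand for lower solubility and higher numbers for higher solubility), compound 3 gives 18 ug/mL and compound 4 gives 16 ug/mL. In the physicochemical assay the same change gives a 1.1-fold lower number from compound 3 to compound 4 (0.05 log units; within the scatter), so the solubility read-out does not separate the pair and only the half-life shifts. Nothing measured on these compounds accounts for the step in half-life.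

As far as these compounds go, whether the mirror-image methyl at this carbon gives the same step remains open. Also open, from the compounds shown here alone, is how a larger group there, such as ethyl or hydroxymethyl, would read in either assay.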